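Cytotoxicity notes on the amide series: benzyl for dichlorophenyl

This account rests on a few compounds, and the source may have more. Where it says the series, first, only, none or still open, it means among the compounds named here.

Compound 1 `CC(Sc1nnc(-c2ccncc2)s1)C(=O)Nc1c(Cl)cccc1Cl` and compound 2 `O=C(CCSc1nnc(-c2ccncc2)s1)Nc1ccccc1` share their core with compound 3 `O=C(CSc1nnc(-c2ccncc2)s1)Nc1c(Cl)cccc1Cl` and with the unmeasured compound 4 `O=C(CSc1nnc(-c2ccncc2)s1)NCc1ccccc1`. In an ADME assay on HepG2 cells (Homo sapiens) for cytotoxicity, with a stated time of 3 days (a higher number here means that more compound is tolerated, a lower number that less compound is tolerated), compound 1 gives > 50000 nM, which is a limit of the assay and not a number. In this assay compound 2 gives > 50000 nM, again a limit rather than a number. In this assay compound 3 gives "not determined" (no result reported), so it has no result of its own; it can be placed only against the other two members of the set, which both sit at the limit of > 50000 nM in this assay, at which 2 of the 3 values shown sit. Among the measured compounds shown here, no pair of measured compounds differing in a single place is available, so nothing is known about how any one change moves the read-out in this assay.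

Compound 4 differs from compound 3 by benzyl in place of 2,6-dichlorophenyl on an amide-type nitrogen. Given that compound 1 and compound 2 both reach (the limit of > 50000 nM in this assay, at which 2 of the 3 values shown sit), a step from compound 3 to compound 4 beyond the scatter in either direction is not expected; the expectation is that compound 4 also sits at the limit. Compound 4 is estimated at 60000 nM in this assay, in a range from 20000 nM to 150000 nM, with a limit rather than a number as the likelier outcome.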

Compound 4, half-maximal cytotoxic concentration: 17700 nM
Compound 4: middle estimate off by 3.4-fold (0.53 log units), on the high side, outside the stated range (below it).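

No step can be read from compound 3 to compound 4, since compound 3 has no result of its own in this assay. The compounds shown leave open how benzyl in place of 2,6-dichlorophenyl on the amide-type nitrogen moves the read-out, and compound 1 and compound 2 offer only a limit: the limit of > 50000 nM in this assay, at which 2 of the 4 values shown sit.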